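A few compounds are considered here, and "the series" means these few. Any claim that something is new, unique, unknown or untested is made for them only; others in the source may bear on it.

Compound 1 `C[C@]1(CN2CCc3nc(-c4ccc(OC(F)(F)F)cc4)ccc3C2)Cn2cc([N+](=O)[O-])nc2O1` has no result in an ADME assay on Vero cells (Chlorocebus sabaeus) for cytotoxicity, read by MTT assay, with a stated time of 72 h (on this read-out higher numbers stand for lower toxicity in this test and lower numbers for higher toxicity in this test), and stands as "not determined" (no result reported). Compound 2 `C[C@]1(CN2CCc3nc(C(F)(F)F)ccc3C2)Cn2cc([N+](=O)[O-])nc2O1` likewise stands as "not determined" (no result reported) in this assay. Compound 3 `C[C@]1(CN2CCc3nc(-c4cccc(F)c4)ccc3C2)Cn2cc([N+](=O)[O-])nc2O1` reaches only a limit of this assay, reported as > 32 ug/mL.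

Of the three compounds, compound 3 is thus the only one with any entry in this assay, and that entry is a limit rather than a number: it sits at the limit of > 32 ug/mL in this assay, at which 1 of the 3 values shown sits, the other two entries carry no value at all. Going by the values given here, there is no pair of measured compounds differing in one place, so no measured step can be described.

Compound 4 `C[C@]1(CN2CCc3nc(-c4cc(F)ccc4F)ccc3C2)Cn2cc([N+](=O)[O-])nc2O1` differs from compound 3 by fluoro in place of hydrogen on an aromatic carbon. With nothing measured on this kind of change, and with compound 3 itself known only as a limit, no step beyond the usual scatter is expected in this assay in either direction. Compound 4 is therefore estimated at 40 ug/mL, within a range from 20 ug/mL to 100 ug/mL, which amounts to an expected step that the limit leaves unreadable from compound 3 to compound 4 of no real size. It is expected that this assay will most likely again report only a limit for compound 4 rather than a single number.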

Compound 4, half-maximal cytotoxic concentration: > 32 ug/mL
Compound 4 ended at the assay's limit; the forecaster's own chance of this, stated with the estimate: 75%; the middle value does not contradict the limit.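

In this assay, no step can be read from compound 3 to compound 4, since both entries are limits of the assay and not numbers: the limit of > 32 ug/mL in this assay, at which 2 of the 4 values shown sit.

The compounds shown leave open how large the half-maximal cytotoxic concentration of either compound actually is, and whether fluoro in place of hydrogen on an aromatic carbon changes it at all.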